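Swapping the group on the amide-type nitrogen of compound 3

The source may report more compounds than this note shows. Statements on the series, on what has been measured and on what is new or still open speak of the compounds shown alone.

Of the compounds shown here, three sharing one core have been measured in a functional assay on HepG2 cells (Homo sapiens) for cytotoxicity, read by MTT assay, with a stated time of 48 h; a lower number here means a stronger inhibitor, a higher number a weaker inhibitor. Compound 1 `Cc1n[nH]c2c1C(c1ccc(N(C)C)cc1)C(C(=O)NN)=C(N)N2` gives 66400 nM, compound 2 `Cc1n[nH]c2c1C(c1ccc(N(C)C)cc1)C(C(=O)NNC(N)=S)=C(N)N2` gives 6320 nM, and compound 3 `Cc1n[nH]c2c1C(c1ccc(N(C)C)cc1)C(C(=O)N/N=C/c1ccc(Cl)cc1)=C(N)N2` gives 39500 nM. Compound 3 therefore lies within the scatter of compound 1 and has a clearly higher number than compound 2.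

Compound 4 `Cc1n[nH]c2c1C(c1ccc(N(C)C)cc1)C(C(=O)N/N=C1/C(=O)Nc3ccccc31)=C(N)N2` keeps the shared core but changes the group on the amide-type nitrogen: a group of 11 heavy atoms (8 carbon, 2 nitrogen, 1 oxygen; one five-membered non-aromatic ring with 1 hetero atom, one six-membered aromatic ring of carbon only) in place of a group of 9 heavy atoms (7 carbon, 1 nitrogen, 1 chlorine; one six-membered aromatic ring of carbon only), on an amide-type nitrogen. Both groups hold one six-membered aromatic ring of carbon only, and the entering group also has one five-membered non-aromatic ring with 1 hetero atom.

The closest evidence is a 1.7-fold lower number from compound 1 to compound 3 (0.23 log units; within the scatter), where the group now leaving entered at this place. The larger steps, an 11-fold lower number from compound 1 to compound 2 (1.02 log units; beyond the scatter) and a 6.3-fold higher number from compound 2 to compound 3 (0.80 log units; beyond the scatter), both involve the ring-free group of compound 2, which compound 4 does not carry, so they bear on this change only weakly. For the measured compounds named here, no measured step shows the effect of the five-membered ring. In this assay, no step beyond the scatter is therefore expected, though a slightly lower number is thought more likely than a higher one. The estimated step is a 1.8-fold lower number from compound 3 to compound 4 (0.25 log units; within the scatter). For compound 4 the estimate is 22000 nM, with an expected range from 7000 nM to 65000 nM.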

Compound 4, half-maximal inhibitory concentration: 57900 nM
The estimate for compound 4 lay 2.6-fold (0.42 log units) below the measured number; the range from low to high includes it.
By their numbers in this assay, from the lowest: compound 2; then compounds 3, 4 and 1 (each within the scatter of the next).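

In this assay, replacing the group with one six-membered aromatic ring of carbon only by the larger group that also holds a five-membered non-aromatic ring with 1 hetero atom gives a 1.5-fold higher number from compound 3 to compound 4 (0.17 log units; within the scatter), and the same position gives a 1.1-fold lower number from compound 1 to compound 4 (0.06 log units; within the scatter), so neither ring-bearing group on the amide-type nitrogen separates from the parent with only a nitrogen atom at this place. The ring-free group of compound 2 remains apart, with a 9.2-fold higher number from compound 2 to compound 4 (0.96 log units; beyond the scatter), and compound 2 now has the lowest number, with its steps to all three others beyond the scatter. Nothing available explains why the groups at this position differ or coincide.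

The compounds shown leave open whether the sulfur of the ring-free group matters, since a urea group with oxygen in its place, or a simple acetyl group, would separate the sulfur from the rest of that group. From the compounds shown here alone, it also remains open whether a ring-bearing group joined through a thiourea, rather than through a carbon-nitrogen double bond, would keep the lower number seen for compound 2.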